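Removing a Trifluoromethyl Group from an Anticonvulsant Amide

A few compounds are considered here, and "the series" means these few. Any claim that something is new, unique, unknown or untested is made for them only; others in the source may bear on it.

Compound 1, `CCC(C(=O)N1CCN(c2ccccc2Cl)CC1)N1C(=O)CCC1=O`: in a functional assay on the whole organism (strain Swiss) with Mus musculus as the target, in the maximal electroshock model, with a stated time of 2 h, at a dose of 300 mg/kg by the intraperitoneal route (on this read-out lower numbers stand for a weaker effect and higher numbers for a stronger effect at the one dose given), compound 1 gives 0%.
Compound 2, `CCC(C(=O)N1CCN(c2cccc(C(F)(F)F)c2)CC1)N1C(=O)CCC1=O`: in this assay compound 2 gives 50%.

Of the compounds shown here, two have been measured so far, and compound 2 holds the higher of the two numbers; the gap that separates it from compound 1 lies beyond the usual scatter of this read-out. Both share the same core, and they differ only in what is attached to the phenyl ring on the piperazine.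

The next compound, compound 3, `CCC(C(=O)N1CCN(c2ccccc2)CC1)N1C(=O)CCC1=O`, is reached from compound 2 by a single change: hydrogen in place of trifluoromethyl on an aromatic carbon. Going by the values given here, no pair of measured compounds differs in one place, so the size of this step is not known from earlier numbers.

Since compound 1, which also lacks a trifluoromethyl group, gives 0%, a loss of effect in this assay is expected. The expected step is a number 30 percentage points lower from compound 2 to compound 3 (beyond the scatter), a decrease beyond the scatter. Compound 3 is estimated to give 20%, ranging from 0% to 50%.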

Compound 3, a percentage reported as activity, at one dose (the size of the read-out at that dose, not a potency): 25%
The estimate for compound 3 lay 5 percentage points below the measured number, and the stated range covers the measured number.
By their numbers in this assay, from the lowest: compound 1; then compound 3; then compound 2.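

Trifluoromethyl is not required for an effect in this assay, since hydrogen in its place gives a number 25 percentage points lower from compound 2 to compound 3 (beyond the scatter) and leaves part of the effect in place. Hydrogen in place of chloro moves the other way, with a number 25 percentage points higher from compound 1 to compound 3 (beyond the scatter), so the compound with neither group falls between the two that carry one, and a substituent on this aromatic ring can go with either a higher or a lower number. Nothing available explains why these two groups differ in this way.

From the compounds shown here alone, it remains open whether the higher number of compound 2 is specific to trifluoromethyl or would also appear with another group on the same aromatic carbon, such as methyl, methoxy or a nitrile. Going by these compounds, the effect of chloro on that carbon also remains unknown.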